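The source may hold more compounds than are shown below. What is called first, only, known or untested is meant among the compounds shown, and "the series" means these compounds.

Measured compounds:
- compound 1, `Fc1cccc(NC(=S)N/N=C/c2ccc3ccccc3n2)c1`: in a functional assay on SGC-7901 cells (Homo sapiens) for antiproliferative activity, read by sulforhodamine B assay, with a stated time of 72 h (a higher number here means a weaker inhibitor, a lower number a stronger inhibitor), compound 1 gives 79900 nM
- compound 2, `N#Cc1ccc(NC(=S)N/N=C/c2ccc3ccccc3n2)cc1`: in this assay compound 2 gives 23700 nM
- compound 3, `Cc1ccccc1NC(=S)N/N=C/c1ccc2ccccc2n1`: in this assay compound 3 returns only the limit > 100000 nM, not a number

Compound 3 therefore stands where the assay stops reporting numbers: its entry is the limit of > 100000 nM in this assay, at which 1 of the 3 values shown sits, a limit of this assay and nothing more precise. Compound 4, `S=C(N/N=C/c1ccc2ccccc2n1)Nc1cccc(Br)c1`, differs from compound 3 in one place: 3-bromophenyl in place of 2-methylphenyl on an amide-type nitrogen. Among the compounds with values here, two measured steps bear on this change. The step of an at least 1.2-fold higher number from compound 1 to compound 3 (0.09 log units; that floor lies within the scatter) shows that 3-fluorophenyl and 2-methylphenyl give readings close to one another, while an at least 4.2-fold higher number from compound 2 to compound 3 (0.62 log units; beyond the scatter) shows 4-cyanophenyl giving the clearly lower number. Compound 4 carries 3-bromophenyl, whose nearest measured relative is the 3-fluorophenyl of compound 1. The expected step of an at least 1.3-fold lower number from compound 3 to compound 4 (0.12 log units; that floor lies within the scatter) is accordingly small, and because compound 3 sits at the limit of > 100000 nM in this assay, at which 1 of the 3 values shown sits, its direction cannot be fixed. Compound 4 is estimated at 75000 nM, within the range 30000 nM to 180000 nM, with a real chance that it too returns only a limit.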

Compound 4, half-maximal inhibitory concentration: 78600 nM
Beside the measured number, compound 4's estimate is 1.0-fold (0.02 log units) below it; the range from low to high includes it.
By their numbers in this assay, from the lowest: compound 2; then compounds 4 and 1 (each within the scatter of the next). At a limit, above all of these: compound 3.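

In this assay, bromo in place of fluoro on an aromatic carbon leaves the reading within the scatter, with a 1.0-fold lower number from compound 1 to compound 4 (0.01 log units; within the scatter). The 4-cyanophenyl group keeps the clearly lower number against 3-bromophenyl, with a 3.3-fold higher number from compound 2 to compound 4 (0.52 log units; beyond the scatter). The step of an at least 1.2-fold lower number from compound 3 to compound 4 (0.10 log units; that floor lies within the scatter) is only a floor, and how far 3-bromophenyl and 2-methylphenyl truly lie apart cannot be read, because compound 3 rests at a limit: the limit of > 100000 nM in this assay, at which 1 of the 4 values shown sits.

As far as these compounds go, whether the lower number of compound 2 goes with the nitrile itself or with its place on the ring stays open. Also open, from the compounds shown here alone, is how an amine or a carboxylic acid on this phenyl ring, or a longer chain in place of the ring, would read in this assay.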